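A few compounds are considered here, and "the series" means these few. Any claim that something is new, unique, unknown or untested is made for them only; others in the source may bear on it.

In an ADME assay (liver) for metabolic stability, with Liver microsome (Homo sapiens) as the target, using microsomes and NADPH, with a stated time of 30 min, tested at 1 uM; a higher number here means faster removal of the compound, a lower number slower removal:
Compound 1 `Nc1ccc(S(=O)(=O)N2CCN(c3ncc(C(O)(C(F)(F)F)C(F)(F)F)cc3-c3ccncc3)CC2)cn1`: 15 mL.min-1.g-1
Compound 2 `Nc1ccc(S(=O)(=O)N2CCN(c3ncc(C(O)(C(F)(F)F)C(F)(F)F)cc3-c3ccc4scnc4c3)CC2)cn1`: 39 mL.min-1.g-1

Compound 2 holds the higher of the two numbers. Compound 3 `Nc1ccc(S(=O)(=O)N2CCN(c3ncc(C(O)(C(F)(F)F)C(F)(F)F)cc3-c3ccc4c(c3)CC(=O)N4)CC2)cn1` differs from it as follows: a group of 10 heavy atoms (8 carbon, 1 nitrogen, 1 oxygen; one five-membered non-aromatic ring with 1 hetero atom, one six-membered aromatic ring of carbon only) in place of a group of 9 heavy atoms (7 carbon, 1 nitrogen, 1 sulfur; one five-membered aromatic ring with 2 hetero atoms, one six-membered aromatic ring of carbon only), on an aromatic carbon. Among the measured compounds shown here, only one measured step bears on this change, a 2.6-fold higher number from compound 1 to compound 2 (0.41 log units; beyond the scatter), which is modest and beyond the scatter. For the measured compounds named here, that step replaced pyridin-4-yl with 1,3-benzothiazol-5-yl on an aromatic carbon, and no measurement yet covers the entering group. A modest drop is therefore expected, of about the same size or smaller, with the expected change being a 1.6-fold lower number from compound 2 to compound 3 (0.21 log units; within the scatter). For compound 3 the estimated value is 24 mL.min-1.g-1, with an expected range of 11 mL.min-1.g-1 to 50 mL.min-1.g-1.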

Compound 3, intrinsic clearance in microsomes: < 14 mL.min-1.g-1
Compound 3: no number, only a limit; the forecaster's own chance of this, stated with the estimate: 3%; middle value at least 1.7-fold (0.23 log units) from the limit.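

In this assay, putting the group with the five-membered non-aromatic ring in place of 1,3-benzothiazol-5-yl gives an at least 2.7-fold lower number from compound 2 to compound 3 (0.44 log units; beyond the scatter), so not every two-ring group at this position keeps the higher number. Compound 3 gives only a limit of the assay, not a number: the limit of < 14 mL.min-1.g-1 in this assay, at which 1 of the 3 values shown sits. Against pyridin-4-yl the step reads an at least 1.0-fold lower number from compound 1 to compound 3 (0.02 log units; that floor lies within the scatter), so that pair cannot be put in order.

The compounds shown leave open whether the carbonyl or the amide hydrogen of the entering group goes with the drop. On these data alone, whether a simple amine or a carboxylic acid on this aromatic carbon would give a similar number also stays open.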